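Swapping the substituent on compound 2

The source may hold more compounds than are shown below. What is called first, only, known or untested is meant among the compounds shown, and "the series" means these compounds.

Among the measured compounds shown here, in a physicochemical assay for lipophilicity, using the shake flask method, in phosphate buffer, measured as octanol-water partition, with a stated time of 30 min, at pH 7.4 (on this read-out lower numbers stand for lower lipophilicity and higher numbers for higher lipophilicity), compound 1 (`CN(C)Cc1ccc(C(=O)Nc2cnc(NCc3c(F)ccc4c3CCO4)n3cnnc23)cc1`) gives 1.8 as the lower of the two numbers so far. Compound 2 (`CC(=O)N1CCC(c2cnc(NCc3c(F)ccc4c3CCO4)c3cn[nH]c(=O)c23)CC1`) gives 2.9 as the higher, and the gap between them lies beyond the usual scatter. These two compounds differ in more than one place, so the data hold no measured single change to serve as a guide. Compound 3 (`Cc1ncccc1-c1cnc(NCc2c(F)ccc3c2CCO3)c2cn[nH]c(=O)c12`) has 2-methylpyridin-3-yl in place of 1-acetylpiperidin-4-yl on an aromatic carbon. For the measured compounds named here, with no precedent for this exchange, only a slight upward move is expected in this assay and nothing beyond the scatter. The estimated change is a number 0.10 log units higher from compound 2 to compound 3 (within the scatter) and would stay within that scatter. Compound 3 is expected at 3 with an estimated range from 2.5 to 3.5 for now.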

Compound 3, distribution coefficient: 3
For compound 3 middle estimate and measured number coincide at the digits printed; measured number inside the range.
By their numbers in this assay, from the lowest: compound 1; then compounds 2 and 3 (each within the scatter of the next).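

In this assay, among the compounds shown here, the first single change that can be read gives a number 0.10 log units higher from compound 2 to compound 3 (within the scatter). On an aromatic carbon of this six-membered aromatic ring with 1 nitrogen, a six-membered non-aromatic ring with 1 hetero atom and a six-membered aromatic ring with 1 hetero atom therefore cannot be told apart on this read-out, even though the 1-acetylpiperidin-4-yl carries a double bond outside aromatic rings and the 2-methylpyridin-3-yl does not. Nothing on hand accounts for this result.

As far as these compounds go, whether a different kind of group at this position, such as a carboxylic acid or an open alkyl chain, would give a step beyond the scatter remains open. Compound 1 differs from the others in more than one place, so no single part of its structure can be tied to its number.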